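The compounds below may be only part of what the source reports. "The series", "measured", "known", "first", "only" and "open" are said of these compounds alone.

Compound 1 `CCSC(=O)C1=C(C)NC(=O)NC1c1ccsc1`: 11%
Compound 2 `CC1=C(C(=O)OC2CCCCC2)C(c2ccsc2)NC(=O)N1`: 8%

In an assay on membranes from CHO cells for displacement of a labelled ligand from adenosine receptor A1 (Homo sapiens), read by scintillation counting, with a stated time of 60 min, tested at 1 uM (a lower number here means less inhibition, a higher number more inhibition at the concentration tested (going by the name of the read-out)), compound 2 stands lowest of the two numbers, with compound 1 nearest, a number 3 percentage points lower from compound 1 to compound 2 (within the scatter). Compound 3 `CC1=C(C(=O)OCC2CC2)C(c2ccsc2)NC(=O)N1` is reached from compound 2 by one change: cyclopropylmethyl in place of cyclohexyl on an oxygen next to a carbonyl group. Among the measured compounds shown here, no measured step touches this oxygen; the only step available, a number 3 percentage points lower from compound 1 to compound 2 (within the scatter), alters the carbonyl neighbour instead and stays within the scatter. Both measured values sit at the weak end of this assay , so for compound 3 no step beyond the scatter is expected, a number 1 percentage points higher from compound 2 to compound 3 (within the scatter). Compound 3 is therefore estimated at 9%, within -3% to 21%.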

Compound 3, a percentage reported as inhibition, at one concentration (the size of the read-out at that concentration, not a potency): 39%
Estimate against measurement, compound 3: 30 percentage points below; the measured number lies above the stated range.
By their numbers in this assay, from the lowest: compounds 2 and 1 (each within the scatter of the next); then compound 3.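

The group on an oxygen next to a carbonyl group clearly matters in this assay: cyclopropylmethyl in place of cyclohexyl gives a number 31 percentage points higher from compound 2 to compound 3 (beyond the scatter). The outcome of replacing ethylsulfanyl on a carbonyl carbon also depends on what enters, since cyclopropylmethoxy gives a number 28 percentage points higher from compound 1 to compound 3 (beyond the scatter), while cyclohexyloxy gave only a number 3 percentage points lower from compound 1 to compound 2 (within the scatter). Nothing available accounts for this rise. From the compounds shown here alone, it remains open whether the three-membered ring itself counts or only the group's size, a question that a straight butyl chain on the same oxygen could address.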